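The source may report more compounds than this note shows. Statements on the series, on what has been measured and on what is new or still open speak of the compounds shown alone.

Compound 2 `O=c1[nH]cc(S(=O)(=O)Nc2ccc(-c3cn(-c4ccccc4)nn3)cc2)c(=O)[nH]1` stands highest of the two numbers recorded in a functional assay on SGC-7901 cells (Homo sapiens) for antiproliferative activity, read by MTT assay, with a stated time of 24 h; a lower number here means a stronger inhibitor, a higher number a weaker inhibitor: in this assay compound 2 gives 18800 nM. Its nearest neighbour, compound 1 `O=c1[nH]cc(S(=O)(=O)Nc2ccccc2-c2cn(-c3cccc(Cl)c3)nn2)c(=O)[nH]1`, in this assay gives 2270 nM, a number beyond the scatter below that of compound 2; as the two compounds differ in more than one place, the pair shows nothing more than that. Compound 3 `Cc1ccc(-n2cc(-c3ccc(NS(=O)(=O)c4c[nH]c(=O)[nH]c4=O)cc3)nn2)cc1` has not yet been measured in this assay. It arises from compound 2 by methyl in place of hydrogen on an aromatic carbon. Among the measured compounds shown here, no measured pair carries this change, so the step has to be estimated: one no larger than the scatter is expected, leaning, if anywhere, towards a lower number. The estimated step is a 1.3-fold lower number from compound 2 to compound 3 (0.13 log units; within the scatter). Compound 3 is thus expected to give 14000 nM in this assay, within a range from 5500 nM to 36000 nM.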

Compound 3, half-maximal inhibitory concentration: 8350 nM
Beside the measured number, compound 3's estimate is 1.7-fold (0.22 log units) above it; measured number inside the range.
By their numbers in this assay, from the lowest: compound 1; then compound 3; then compound 2.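

Among the compounds shown here, the change from phenyl to 4-methylphenyl gives the first step in this assay that can be read at a single place: a 2.3-fold lower number from compound 2 to compound 3 (0.35 log units; beyond the scatter). It shows that this position, on an aromatic carbon para to a large group, is not indifferent to methyl in place of hydrogen, and that this one added carbon moves the number modestly towards a stronger inhibitor. No measurement shown here offers an explanation for this step.

From the compounds shown here alone, this is one pair, so it remains open whether the same step would appear with the methyl placed elsewhere on that ring or in another compound of the series. Going by these compounds, it is also open how this position would respond to a longer chain such as ethyl, to a methoxy group, to an amine or to a carboxylic acid.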